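The source may report more compounds than this note shows. Statements on the series, on what has been measured and on what is new or still open speak of the compounds shown alone.

Measured compounds in a functional assay on NALM-6 cells (Homo sapiens) for antiproliferative activity; a lower number here means a stronger inhibitor, a higher number a weaker inhibitor:
compound 1, `C=C1C(=O)ON(C)C1C(C)C`, gives 4160 nM
compound 2, `C=C1C(=O)ON(C)C1C(C)CCC`, gives 340 nM
compound 3, `C=C1C(=O)ON(C)C1c1ccc(C)cc1`, gives 5800 nM

Among these three, compound 3 stands at the highest number; compound 1 sits close to it, within the scatter, while compound 2 lies well apart, beyond the scatter. Among the compounds with values here, the only single-point step in the set, a 12-fold lower number from compound 1 to compound 2 (1.09 log units; beyond the scatter), concerns a chain substituent and not the aromatic ring. Compound 4, `C=C1C(=O)ON(C)C1c1ccc([N+](=O)[O-])cc1`, differs from compound 3 by nitro in place of methyl on an aromatic carbon. Within the data shown here, no measured step bears on such an exchange on the aromatic ring, so the step from compound 3 is expected to stay within the scatter: a 1.2-fold lower number from compound 3 to compound 4 (0.06 log units; within the scatter). Compound 4 is therefore estimated at 5000 nM, with a range from 1500 nM to 16000 nM.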

Compound 4, half-maximal inhibitory concentration: 5200 nM
For compound 4 the middle estimate is 1.0-fold (0.02 log units) below the measured one; the range from low to high includes it.
By their numbers in this assay, from the lowest: compound 2; then compounds 1, 4 and 3 (each within the scatter of the next).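

In this assay, nitro in place of methyl on an aromatic carbon, para to a group of 8 heavy atoms, amounts to a 1.1-fold lower number from compound 3 to compound 4 (0.05 log units; within the scatter) and so leaves the number within the scatter. Within the data shown here, this is the first measured change on the aromatic ring, since the earlier step concerned only a chain substituent. No evidence at hand bears on this result. Going by these compounds, whether an amine or a carboxylic acid on this same ring carbon would also stay within the scatter remains open. So does the effect of a longer chain there.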